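Trimethoxy series: removing one methoxy from compound 3

This account rests on a few compounds, and the source may have more. Where it says the series, first, only, none or still open, it means among the compounds named here.

Values in an ADME assay on HBL-100 cells (Homo sapiens) for cytotoxicity, read by MTT assay, with a stated time of 72 h (on this read-out higher numbers stand for weaker inhibition and lower numbers for stronger inhibition), are as follows
- compound 1 `COc1cc2oc(=O)cc(-c3ccc4c(c3)CCO4)c2c(OC)c1OC` gives > 50000 nM as a limit of the assay
- compound 2 `COc1cc2oc(=O)cc(-c3cccc4[nH]ccc34)c2c(OC)c1OC` gives 53000 nM as a number
- compound 3 `COc1cc2oc(=O)cc(-c3ccc4c(ccn4C)c3)c2c(OC)c1OC` gives 98 nM as a number

Compound 1 stands at a limit and has no exact number. Compound 3 holds the lower of the two exact numbers, and its gap to compound 2 lies well beyond the scatter.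

Compound 4 `COc1cc(OC)c2c(-c3ccc4c(ccn4C)c3)cc(=O)oc2c1` has hydrogen in place of methoxy on an aromatic carbon, ortho to two methoxy groups hydrogen in place of methoxy on an aromatic carbon and otherwise matches compound 3. For the measured compounds named here, no measured pair isolates this change, so the expectation rests on indirect evidence. Compound 3 (98 nM) starts low, while compound 2 (53000 nM) shows how widely numbers can spread among close relatives. The expected step of a 12-fold higher number from compound 3 to compound 4 (1.09 log units; beyond the scatter) is a clear rise in this assay and beyond the scatter, pointing to weaker inhibition. For compound 4 the estimated value is 1200 nM with an expected range (150 nM to 15000 nM).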

Compound 4, half-maximal inhibitory concentration: 73 nM
For compound 4 the middle estimate is 16-fold (1.22 log units) above the measured one, outside the stated range (below it).
By their numbers in this assay, from the lowest: compounds 4 and 3 (each within the scatter of the next); then compound 2.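

Hydrogen in place of methoxy on an aromatic carbon, ortho to two methoxy groups, gives a 1.3-fold lower number from compound 3 to compound 4 (0.13 log units; within the scatter) in this assay. For the compounds shown here, this is the first matched pair at this position, and it shows that, with the rest of compound 3 held constant, the low number in this assay does not depend on this methoxy. The data shown give no reason why the position accepts the change so readily.

Hydrogen and methoxy are the only groups shown at this position, so the outcome with an amine, a carboxylic acid or a longer alkoxy chain there remains open. Going by these compounds alone, the two remaining methoxy groups have no step of their own, so what each one contributes in this assay cannot be read.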